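This account rests on a few compounds, and the source may have more. Where it says the series, first, only, none or still open, it means among the compounds named here.

Measured in a functional assay on HL-60 cells (Homo sapiens) for cytotoxicity, read by WST assay, with a stated time of 48 h; on this read-out lower numbers stand for stronger inhibition and higher numbers for weaker inhibition:
- compound 1 `COc1cc(C(c2ccc(O)c(OC)c2)[C@@H](C)C(C)C)ccc1O`: 20000 nM
- compound 2 `COc1cc(C(c2ccc(O)c(OC)c2)[C@@H](CO)C(C)C)ccc1O`: > 100000 nM, a limit of the assay
- compound 3 `COC[C@@H](C(C)C)C(c1ccc(O)c(OC)c1)c1ccc(O)c(OC)c1`: 54000 nM

Compound 3 has the higher of the two actual numbers, and compound 1 is its nearest neighbour. The change to compound 4 `CC[C@H](C(C)C)C(c1ccc(O)c(OC)c1)c1ccc(O)c(OC)c1` is 1-isopropylpropyl in place of 1-(methoxymethyl)-2-methylpropyl on a saturated chain carbon bound to two aromatic carbons. The chain of compound 4 carries no oxygen, as in compound 1. Going by the values given here, two measured steps bear on this: a 2.7-fold higher number from compound 1 to compound 3 (0.43 log units; beyond the scatter) and an at least 5.0-fold higher number from compound 1 to compound 2 (0.69 log units; beyond the scatter). Both introduced oxygen and raised the number, so removing it should lower the number by a modest amount. In this assay the expected change is a 2.7-fold lower number from compound 3 to compound 4 (0.43 log units; beyond the scatter). For compound 4 the estimated value is 20000 nM, with an expected range of 8000 nM to 50000 nM.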

Compound 4, half-maximal inhibitory concentration: 16000 nM
Compound 4: the middle estimate sits 1.3-fold (0.10 log units) above what was measured; the range from low to high includes it.
By their numbers in this assay, from the lowest: compounds 4 and 1 (each within the scatter of the next); then compound 3. At a limit, above all of these: compound 2.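

In this assay, on a saturated chain carbon bound to two aromatic carbons, 1-isopropylpropyl in place of 1-(methoxymethyl)-2-methylpropyl gives a lower number (a 3.4-fold lower number from compound 3 to compound 4 (0.53 log units; beyond the scatter)). Adding one carbon to the chain, from 1,2-dimethylpropyl to 1-isopropylpropyl, shows no change that can be read (a 1.3-fold lower number from compound 1 to compound 4 (0.10 log units; within the scatter)). The step from the 1-(hydroxymethyl)-2-methylpropyl chain is only a floor (an at least 6.2-fold lower number from compound 2 to compound 4 (0.79 log units; beyond the scatter)), as its starting value is a limit of the assay: the limit of > 100000 nM in this assay, at which 1 of the 4 values shown sits.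

As far as these compounds go, how a longer chain would read at this position remains open. So does an amine or a carboxylic acid on the chain.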